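The source may hold more compounds than are shown below. What is called first, only, known or untested is meant among the compounds shown, and "the series" means these compounds.

Compound 3 `CCCn1c(-c2ccco2)nc2c(NCc3ccccc3)ncnc21` gives 402 nM in an assay on CHO cells for displacement of a labelled ligand from transmembrane domain-containing protein TMIGD3 (Homo sapiens) (a lower number here means a stronger inhibitor, a higher number a weaker inhibitor), the lowest of the three numbers at hand, though compound 1 `CCCn1c(-c2ccco2)nc2c(N)ncnc21` with 790 nM sits close to it, and only compound 2 `CCCn1cnc2c(NCCCc3ccccc3)ncnc21` with 30000 nM lies far away. Compound 4 `CCCn1c(-c2ccco2)nc2c(NCCCc3ccccc3)ncnc21` differs from compound 3 by phenethyl in place of phenyl on a saturated chain carbon bound to a nitrogen on an aromatic ring. Among the compounds with values here, only one measured step bears on this change: a 2.0-fold lower number from compound 1 to compound 3 (0.29 log units; within the scatter), which shows that attaching the benzyl group in compound 3 left the number where compound 1 had it. Compound 2 carries the same chain as compound 4 but differs from it at another point of the core, and its high number is read with that in mind rather than as a direct guide. Since the step from compound 1 to compound 3 stayed within the scatter, a modest weakening is expected on lengthening the chain further, so that the estimated step is a 3.7-fold higher number from compound 3 to compound 4 (0.57 log units; beyond the scatter). Compound 4 is therefore expected to give about 1500 nM in this assay, with a plausible range from 400 nM to 6000 nM.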

Compound 4, inhibition constant: 959 nM
Compound 4: the middle estimate sits 1.6-fold (0.19 log units) above what was measured, and the stated range covers the measured number.
By their numbers in this assay, from the lowest: compounds 3, 1 and 4 (each within the scatter of the next, the first and the last beyond it); then compound 2.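

In this assay, within the data shown here, a 2.4-fold higher number from compound 3 to compound 4 (0.38 log units; beyond the scatter) is the first change to the group on this nitrogen that goes beyond the scatter, so lengthening the chain from benzyl to 3-phenylpropyl does register. Set against hydrogen on the same nitrogen, however, the 3-phenylpropyl group gives a 1.2-fold higher number from compound 1 to compound 4 (0.08 log units; within the scatter), which leaves compound 4 within the scatter of compound 1. With the chain held the same, furan-2-yl in place of hydrogen on an aromatic carbon gives a 31-fold lower number from compound 2 to compound 4 (1.50 log units; beyond the scatter), by far the largest of the steps read so far.

Going by these compounds, it remains open whether furan-2-yl has a similar effect with benzyl or hydrogen on the nitrogen, and how a longer chain or an amine at its end would read. No measurement at hand explains the size of any of these steps.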